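Methoxy for Chloro on a Pyrazolopyridine Breast Cancer Cell Series

A few compounds are considered here, and "the series" means these few. Any claim that something is new, unique, unknown or untested is made for them only; others in the source may bear on it.

The measured compounds:
- compound 1, `Clc1ccc(-c2ccnc3c2c(-c2ccccc2)nn3-c2ccccc2)cc1`, 61100 nM
- compound 2, `COc1ccc(-c2ccnc3c2c(-c2ccccc2)nn3-c2ccccc2)cc1`, 28700 nM
- compound 3, `CN1CCN(c2ccc(-c3c(C#N)c(-c4ccc(Cl)cc4)nc4c3c(-c3ccccc3)nn4-c3ccccc3)cc2)CC1`, 2710 nM

All three were tested in a functional assay on MCF7 cells (Homo sapiens) for inhibition, read by MTT assay, with a stated time of 48 h; a higher number here means a weaker inhibitor, a lower number a stronger inhibitor. Compound 1 and compound 2 share a core and differ only in a single group: methoxy in place of chloro on an aromatic carbon. That change gave a 2.1-fold lower number from compound 1 to compound 2 (0.33 log units; beyond the scatter). Compound 3 carries a core that is not the same as that of compound 1; the difference between the two cores is not broken down here. Among the three, compound 3 gives the lowest number, and its gap to compound 2 and to compound 1 is in each case beyond the scatter.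

Compound 4, `COc1ccc(-c2nc3c(c(-c4ccccc4)nn3-c3ccccc3)c(-c3ccc(N4CCN(C)CC4)cc3)c2C#N)cc1`, has not yet been measured. It differs from compound 3 by methoxy in place of chloro on an aromatic carbon, which is the same change that turned compound 1 into compound 2, made at the same kind of place on the ring. Going by the values given here, from compound 3 to compound 4 a step of about a 1.9-fold lower number from compound 3 to compound 4 (0.29 log units; within the scatter) is expected, resting on the one earlier step of a 2.1-fold lower number from compound 1 to compound 2 (0.33 log units; beyond the scatter) and on the value of compound 3, 2710 nM. For compound 4 the estimate is therefore 1400 nM, expected to lie between 600 nM and 3500 nM.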

Compound 4, half-maximal inhibitory concentration: 2650 nM
Compound 4: the middle estimate sits 1.9-fold (0.28 log units) below what was measured; the measured number falls inside the stated range.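

In this assay, placing methoxy where chloro stood on the core of compound 3 gave a 1.0-fold lower number from compound 3 to compound 4 (0.01 log units; within the scatter), so these two compounds cannot be told apart in this measurement. Set beside the earlier step on the other core, the new step does not differ from it by more than two such steps normally would: the same change on two cores in this assay, a 2.1-fold lower number (0.33 log units; beyond the scatter) from compound 1 to compound 2 and a 1.0-fold lower number (0.01 log units; within the scatter) from compound 3 to compound 4, 2.1-fold (0.32 log units) apart, within the scatter of two such steps. Going by these compounds alone, this means the result does not contradict carrying the change from one core to the other, but it does not prove that the change acts alike on both, as there are only two pairs, and one step lies beyond the scatter while the other lies within it.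

Going by these compounds, what an amine, a carboxylic acid or a longer chain such as ethoxy would give in place of the chloro on either core remains open. The compounds shown also do not separate the features that distinguish the core of compound 3 from the core of compound 1, so which of those features matters for the measured number is unknown.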